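Keeping the acid, adding a carbonyl on the amine chain

The compounds below may be only part of what the source reports. "The series", "measured", "known", "first", "only" and "open" are said of these compounds alone.

Compound 1 `Cc1cn([C@@H]2O[C@H](CO[Si](C)(C)C(C)(C)C)[C@@]3(OS(=O)(=O)C=C3NCCC(=O)O)[C@H]2O[Si](C)(C)C(C)(C)C)c(=O)n(C)c1=O`: 19400 nM
Compound 2 `COC(=O)CCNC1=CS(=O)(=O)O[C@@]12[C@@H](CO[Si](C)(C)C(C)(C)C)O[C@@H](n1cc(C)c(=O)n(C)c1=O)[C@@H]2O[Si](C)(C)C(C)(C)C`: > 250000 nM (a limit of the assay)
Compound 3 `C=C(C)C(=O)NC(=O)NC1=CS(=O)(=O)O[C@@]12[C@@H](CO[Si](C)(C)C(C)(C)C)O[C@@H](n1cc(C)c(=O)n(C)c1=O)[C@@H]2O[Si](C)(C)C(C)(C)C`: 1200 nM

In a functional assay on CCRF-CEM cells (Homo sapiens) (on this read-out higher numbers stand for lower toxicity in this test and lower numbers for higher toxicity in this test), compound 1 gives 19400 nM, the highest of the two numbers obtained; the nearest is compound 3, reached by a 16-fold lower number from compound 1 to compound 3 (1.21 log units; beyond the scatter). Compound 2 yields only a limit, > 250000 nM. Compound 4 `Cc1cn([C@@H]2O[C@H](CO[Si](C)(C)C(C)(C)C)[C@@]3(OS(=O)(=O)C=C3NCC(=O)C(=O)O)[C@H]2O[Si](C)(C)C(C)(C)C)c(=O)n(C)c1=O` differs from compound 1 by carboxycarbonyl in place of carboxymethyl on a saturated chain carbon bound to an amine nitrogen. Among the compounds with values here, no measured step alters this part of the molecule in the same way. The step of an at least 12-fold higher number from compound 1 to compound 2 (1.11 log units; beyond the scatter) shows that masking the acid matters, but compound 4 keeps its acid. The step from compound 1 to compound 4 is therefore expected to stay within the scatter, a 1.0-fold higher number from compound 1 to compound 4 (0.01 log units; within the scatter). Compound 4 is estimated at 20000 nM in this assay, ranging from 6000 nM to 65000 nM.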

Compound 4, half-maximal cytotoxic concentration: 72600 nM
Compound 4: middle estimate off by 3.6-fold (0.56 log units), on the low side, outside the stated range (above it).
By their numbers in this assay, from the lowest: compound 3; then compound 1; then compound 4. At a limit, above all of these: compound 2.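

With the acid kept, carboxycarbonyl in place of carboxymethyl on a saturated chain carbon bound to an amine nitrogen still moves the read-out in this assay, giving a 3.7-fold higher number from compound 1 to compound 4 (0.57 log units; beyond the scatter). This modest shift is far smaller than the large gap to the ((1-methylethenyl)carbonyl)carbamoyl group, seen as a 61-fold higher number from compound 3 to compound 4 (1.78 log units; beyond the scatter). The methyl ester compound 2 also stays apart, with an at least 3.4-fold lower number from compound 2 to compound 4 (0.53 log units; beyond the scatter), but this step rests on a limit, not a number: the limit of > 250000 nM in this assay, at which 1 of the 4 values shown sits.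

On these data alone, whether an amine in place of the acid, or a longer chain carrying the carboxycarbonyl, would shift the number further stays open.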